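Three amides and a thiazolyl analogue awaiting measurement

A few compounds are considered here, and "the series" means these few. Any claim that something is new, unique, unknown or untested is made for them only; others in the source may bear on it.

Compound 1 `COc1ccc(C(=O)Nc2ccccc2C)cc1OC1CCCC1`: 300 nM
Compound 2 `COc1ccc(C(=O)Nc2c(Cl)cccc2Cl)cc1OC1CC2CCC1C2`: 10 nM
Compound 3 `COc1ccc(C(=O)Nc2c(F)cnc(F)c2F)cc1OC1CCCC1`: 85 nM

The three measured compounds share a core that is varied on the amide-type nitrogen. In an assay on isolated protein for inhibition of phosphodiesterase 4A (Sus scrofa) (on this read-out higher numbers stand for weaker inhibition and lower numbers for stronger inhibition), compound 1 gives 300 nM, the highest of the three numbers and therefore the weakest inhibition shown. Compound 3 stands nearest with 85 nM, a gap beyond the scatter, and compound 2 lies furthest with 10 nM, also beyond the scatter.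

Compound 4 `COc1ccc(C(=O)Nc2c(C)nsc2C)cc1OC1CCCC1` has not yet been measured. It differs from compound 1 in one place: 3,5-dimethyl-1,2-thiazol-4-yl in place of 2-methylphenyl on an amide-type nitrogen. Among the measured compounds shown here, no pair of measured compounds shows exactly this kind of exchange, so the step can only be expected from the general picture that the ring on the amide-type nitrogen governs the numbers here. A modest step toward stronger inhibition, near the edge of the scatter, is expected for a 2.0-fold lower number from compound 1 to compound 4 (0.30 log units; within the scatter). Compound 4 is accordingly estimated at 150 nM in this assay, with a range from 40 nM to 600 nM.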

Compound 4, half-maximal inhibitory concentration: 500 nM
The estimate for compound 4 lay 3.3-fold (0.52 log units) below the measured number; the measured number falls inside the stated range.
By their numbers in this assay, from the lowest: compound 2; then compound 3; then compounds 1 and 4 (each within the scatter of the next).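

In this assay the exchange of 2-methylphenyl for 3,5-dimethyl-1,2-thiazol-4-yl on the amide-type nitrogen gives a 1.7-fold higher number from compound 1 to compound 4 (0.22 log units; within the scatter) and so leaves the two compounds indistinguishable on this read-out. This is the first one-place comparison shown at this position. It shows that a six-membered aromatic ring of carbon only can give way to a five-membered aromatic ring with 2 hetero atoms, at the same heavy-atom count and with 2 hydrogen-bond acceptors entering, with no change beyond the scatter. Nothing at hand offers an explanation for this result.

Still open, as far as these compounds go, is how the unsubstituted 1,2-thiazol-4-yl would read, which would show what the two methyl groups contribute. Also open, from the compounds shown here alone, is how a ring bearing an amine or a carboxylic acid would read at this position.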